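The source may report more compounds than this note shows. Statements on the series, on what has been measured and on what is new or still open speak of the compounds shown alone.

Measured compounds in a functional assay on cells (Platelet, Homo sapiens) for inhibition; on this read-out higher numbers stand for weaker inhibition and lower numbers for stronger inhibition:

Compound 1, `CCOC(=O)c1cccc(-c2n[nH]c3ccccc23)c1`: compound 1 gives > 10000 nM, which is a limit of the assay and not a number.
Compound 2, `CCOC(=O)c1ccc(-c2nn(C)c3ccccc23)cc1`: compound 2 gives > 10000 nM, again a limit of the assay.
Compound 3, `CCOC(=O)c1ccc(-c2nn(Cc3ccc(Cl)cc3)c3ccccc23)cc1`: compound 3 gives > 10000 nM, also a limit of the assay.

All three values shown sit at the same limit, as summarised by the limit of > 10000 nM in this assay, at which 3 of the 3 values shown sit. Within this set compound 3 therefore stands at the limit, with no number to place it above or below the other two. Within the data shown here, the one measured step between neighbours, a step that the two limits leave unreadable from compound 2 to compound 3, cannot be read, since both ends are limits.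

Compound 4, `CCOC(=O)c1ccc(-c2nn(Cc3ccc(F)cc3)c3ccccc23)cc1`, is not yet measured in this assay. It differs from compound 3 by fluoro in place of chloro on an aromatic carbon; cut one bond further out, the change reads 4-chlorobenzyl to 4-fluorobenzyl.

Among the measured compounds shown here, no measured step bears on a fluoro for chloro exchange here, and the step into compound 3 itself is unreadable. For the measured compounds named here, the only evidence is that compound 3 and the two compounds around it all sit at the limit. Compound 4 is therefore expected to remain at or near that limit, with a step that the limit leaves unreadable from compound 3 to compound 4 expected to be no step beyond the scatter. The estimate for compound 4 is 20000 nM, with a range from 7000 nM to 60000 nM.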

Compound 4, half-maximal inhibitory concentration: > 10000 nM
Compound 4 ended at the assay's limit (the forecaster's own chance of this, stated with the estimate: 85%); the middle value is on the limit's open side.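

In this assay compound 4 gives > 10000 nM, a limit of the assay and not a number. The steps to compound 4 from compound 2 and from compound 3 therefore cannot be read. The compounds shown leave open how the 4-fluorobenzyl and 4-chlorobenzyl compounds compare, and whether any change to the shared core gives a readable value: the limit of > 10000 nM in this assay, at which 4 of the 4 values shown sit.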